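The source may report more compounds than this note shows. Statements on the series, on what has been measured and on what is new or still open speak of the compounds shown alone.

Measured so far:
compound 1 `Nc1cc(N)c2nc(-c3ccccc3)c(NCc3ccc(Cl)c(Cl)c3)nc2c1` — 53700 nM
compound 2 `COc1ccc(CNc2nc3cc(N)cc(N)c3nc2-c2ccccc2)cc1OC` — a limit only

Compound 1 `Nc1cc(N)c2nc(-c3ccccc3)c(NCc3ccc(Cl)c(Cl)c3)nc2c1` in a functional assay on MCF7 cells (Homo sapiens) for inhibition, read by sulforhodamine B assay, with a stated time of 48 h (a higher number here means a weaker inhibitor of growth, a lower number a stronger inhibitor of growth), gives 53700 nM. For compound 2 `COc1ccc(CNc2nc3cc(N)cc(N)c3nc2-c2ccccc2)cc1OC` the this assay returns only a limit, < 100000 nM. The step that the limit leaves unreadable from compound 1 to compound 2 is therefore not readable, and the limit of < 100000 nM in this assay, at which 1 of the 2 values shown sits, is all that fixes where compound 2 stands in the this assay.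

Compound 3 `COc1cc(CNc2nc3cc(N)cc(N)c3nc2-c2ccccc2)cc(OC)c1OC` differs from compound 2 by methoxy in place of hydrogen on an aromatic carbon. Among the measured compounds shown here, no measured step bears on this change; the single step in the set, from compound 1 to compound 2, gives no size. For the this assay no direction can be argued for the move to compound 3, and the outcome is expected to sit near the limit recorded for compound 2, with a fair chance that only a limit is reported again. Compound 3 is estimated at 60000 nM, with a range from 20000 nM to 150000 nM. The step that the limit leaves unreadable from compound 2 to compound 3 is thus expected to be small.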

Compound 3, concentration for total growth inhibition: < 50200 nM
Compound 3: a limit, no number; the forecaster's own chance of this, stated with the estimate: 50%; middle value at least 1.1-fold (0.07 log units) from the limit.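

Compound 2 and compound 3 both return only limits in this assay, so the step between them cannot be read. The compounds shown leave open whether methoxy in place of hydrogen on an aromatic carbon changes growth inhibition at all, and in which direction.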